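The compounds below may be only part of what the source reports. "The series", "measured", "known", "first", "only" and "open" are said of these compounds alone.

Three compounds that share one core have gone through an ADME assay on U2OS cells (Homo sapiens) for cytotoxicity; a higher number here means that more compound is tolerated, a lower number that less compound is tolerated. In that test, compound 2 `CCSc1ccc(-c2nccc3[nH]c(C(C)(C)O)cc23)cc1` gives 17200 nM, the lower of the two numbers available. Compound 3 `CC(C)(O)c1cc2c(-c3ccsc3)nccc2[nH]1` gives 199000 nM, a gap beyond the usual scatter, so compound 2 is the less tolerated of this pair. Compound 1 `CC(C)(O)c1cc2c(-c3ccc(C#N)cc3)nccc2[nH]1` adds no number, as its result is "not determined" (no result reported).

The next compound, not yet measured, is compound 4 `CC(C)(O)c1cc2c(-c3ccc(C(F)(F)F)cc3)nccc2[nH]1`. It keeps the shared core of compound 2 and changes one group: trifluoromethyl in place of ethylsulfanyl on an aromatic carbon. That carbon belongs to a six-membered aromatic ring of carbon only, and the group sits para to a large group.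

Among the compounds with values here, no measured pair shows this exact swap, so any forecast rests on very little. Within the data shown here, compound 2 stands at the low end of the only two numbers, with 17200 nM, which leaves more room for a rise than for a fall, so a modest rise is expected. The estimated step of a 2.3-fold higher number from compound 2 to compound 4 (0.37 log units; beyond the scatter) lies only slightly beyond the scatter. For compound 4 the estimate is 40000 nM, within an expected range of 12000 nM to 130000 nM.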

Compound 4, half-maximal cytotoxic concentration: 72300 nM
Compound 4: middle estimate off by 1.8-fold (0.26 log units), on the low side, within the range that was stated.
By their numbers in this assay, from the lowest: compound 2; then compound 4; then compound 3.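

Within the data shown here, this is the first pair in this assay that differs in only one place, so it isolates a single change on the shared core: trifluoromethyl in place of ethylsulfanyl, on the aromatic carbon para to a large group, gives a 4.2-fold higher number from compound 2 to compound 4 (0.62 log units; beyond the scatter). The position therefore matters for this read-out, and more compound is tolerated with trifluoromethyl there than with ethylsulfanyl. The swap removes a sulfur-bearing chain and a counted hydrogen-bond acceptor and adds fluorine, but nothing available explains which of these differences, if any, accounts for the step.

A single pair gives the direction of one swap, not a rule for this position, and it cannot separate the role of sulfur from that of fluorine or of group size. On these data alone, how an amine, a carboxylic acid or a longer chain at the same carbon would compare with trifluoromethyl and ethylsulfanyl remains open, as does whether the same swap would have a similar effect on a different core.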